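Two triazine ureas and a morpholine urea yet to be tested

The compounds below may be only part of what the source reports. "The series", "measured", "known", "first", "only" and "open" are said of these compounds alone.

Measured compounds:
compound 1 `CC1(C)N=C(N)N=C(N)N1c1cccc(CNC(=O)Nc2cccc(Cl)c2)c1` — 8.05
compound 2 `CC1(C)N=C(N)N=C(N)N1c1ccc(CCCCc2ccc(S(=O)(=O)F)cc2Cl)cc1` — 7.96

Of the compounds shown here, two sharing the same core have been measured in an assay on isolated protein for inhibition of Dihydrofolate reductase (Mus musculus); on this read-out higher numbers stand for higher potency (the scale is a negative logarithm) and lower numbers for lower potency. Compound 1 `CC1(C)N=C(N)N=C(N)N1c1cccc(CNC(=O)Nc2cccc(Cl)c2)c1` gives 8.05, and compound 2 `CC1(C)N=C(N)N=C(N)N1c1ccc(CCCCc2ccc(S(=O)(=O)F)cc2Cl)cc1` gives 7.96. These two numbers lie within the usual scatter of each other, so neither compound can be set above the other on this read-out; compound 1 simply holds the larger of the two figures.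

Compound 3 `CC1(C)N=C(N)N=C(N)N1c1cccc(CNC(=O)N2CCOCC2)c1` has not yet been measured. Relative to compound 1 it carries a single alteration, (morpholin-4-yl in place of (3-chlorophenyl)amino on a carbonyl carbon). Among the compounds with values here, no measured pair in this set isolates such a change, so there is no directly comparable step to lean on. Still, the group that leaves is an aromatic ring bearing a hydrogen-bond donor, and the group that enters is a smaller non-aromatic ring with an acceptor and no donor. On that basis compound 3 is expected to fall below compound 1 in this assay by a step beyond the scatter, a number 1.25 log units lower from compound 1 to compound 3 (beyond the scatter), giving an estimated value of 6.8, with a likely range from 6 to 7.6.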

Compound 3, logarithm of the reciprocal of the active concentration, log(1/C): 6.43
Compound 3: the middle estimate sits 0.37 log units above what was measured, within the range that was stated.
By their numbers in this assay, from the lowest: compound 3; then compounds 2 and 1 (each within the scatter of the next).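

In this assay the exchange of (3-chlorophenyl)amino for morpholin-4-yl on a carbonyl carbon gives a number 1.62 log units lower from compound 1 to compound 3 (beyond the scatter) and is a large step, so what this carbonyl carbon carries matters to the potency of the series, which the two earlier numbers alone could not show. The change is not a single feature, however: the aromatic ring of carbon only, the chlorine and the hydrogen-bond donor all leave together, while a non-aromatic ring with a hydrogen-bond acceptor enters. No measurement at hand assigns the loss to any one of these features.

The compounds shown leave open which of these differences accounts for the step, and whether the aromatic ring, the donor or the chlorine is the part that counts. A cyclohexylamino group on the same carbonyl carbon would keep the donor without the aromatic ring, a methyl(3-chlorophenyl)amino group would keep the aromatic ring without the donor, and a plain phenylamino group would test the chlorine alone.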